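Closing the Amine Side Chain of Compound 1 into a Ring

The compounds below may be only part of what the source reports. "The series", "measured", "known", "first", "only" and "open" are said of these compounds alone.

Compound 1 `C[C@H](N)C(=O)NCc1cccnc1Oc1ccc(F)cc1F`: 14000 nM
Compound 2 `C[C@H](N)C(=O)NCc1cccnc1N(C)Cc1ccccc1`: "not active" (no number reported)

Within the data shown here, compound 1 holds the only number in an assay on isolated protein for inhibition of protein arginine N-methyltransferase 6 (Homo sapiens) (on this read-out lower numbers stand for stronger inhibition and higher numbers for weaker inhibition), where compound 1 gives 14000 nM. Compound 2 is reported in this assay only as "not active" (no number reported), without a number. Compound 3 `NC1(C(=O)NCc2cccnc2Oc2ccc(F)cc2F)CC1` differs from compound 1 by 1-aminocyclopropyl in place of 1-aminoethyl on a carbonyl carbon. Among the measured compounds shown here, no step between measured compounds is known here, so the size of this change can only be guessed. The expected step is no change at the digits printed from compound 1 to compound 3 (within the scatter), not beyond the scatter. Compound 3 is therefore estimated at 14000 nM, with a range from 5000 nM to 40000 nM.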

Compound 3, half-maximal inhibitory concentration: "not active" (no number reported)
Compound 3: no number reported; no gap can be computed for the estimate.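

Among these compounds, compound 3 is reported in this assay only as "not active" and carries no number, and no step from compound 1 to compound 3 can be read. Nothing shown bears on the reason for this result. The compounds shown leave open how far 1-aminocyclopropyl in place of 1-aminoethyl shifts the inhibition.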